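The source may report more compounds than this note shows. Statements on the series, on what has been measured and on what is new or still open speak of the compounds shown alone.

Measured so far:
Compound 1 `O=c1[nH]c2ccc(-c3csc(-c4ccc(F)c(O)c4)n3)cc2o1` — < 20000 nM
Compound 2 `COc1cc(F)ccc1-c1nc(-c2ccc3[nH]c(=O)oc3c2)cs1` — < 20000 nM

Both values come from an assay on isolated protein for inhibition of protein phosphatase 1D (Homo sapiens), read by malachite green; on this read-out lower numbers stand for stronger inhibition and higher numbers for weaker inhibition. For compound 1 the entry < 20000 nM is a limit of the assay rather than a measured number. For compound 2 the entry < 20000 nM is likewise a limit, not a number. So compound 2 stands at an edge of the scale with no exact position: it is only known that its inhibition is stronger than that edge, and the same holds for compound 1 (the limit of < 20000 nM in this assay, at which 2 of the 2 values shown sit). Nothing is known about how far either one lies beyond it.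

Compound 3 `COCCOCc1cc(F)ccc1-c1nc(-c2ccc3[nH]c(=O)oc3c2)cs1` is the next compound to be tested. Compared with compound 2 it carries (2-methoxyethoxy)methyl in place of methoxy on an aromatic carbon. Going by the values given here, no step between measured compounds is available to calibrate this kind of change, and with compound 2 known only as a limit there is no firm starting number. The expectation for the step from compound 2 to compound 3 in this assay is therefore a step that the limit leaves unreadable from compound 2 to compound 3, that is, no shift beyond the usual scatter. Compound 3 is estimated at 8000 nM, with a range from 1500 nM to 20000 nM.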

Compound 3, half-maximal inhibitory concentration: < 20000 nM
Compound 3 was reported as a limit; the forecaster's own chance of this, stated with the estimate: 50%; the middle value does not contradict the limit.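

No step can be read between compound 2 and compound 3, because neither has an exact number and both values are limits of the assay: the limit of < 20000 nM in this assay, at which 3 of the 3 values shown sit. As far as these compounds go, how strongly compound 1, compound 2 and compound 3 each inhibit in this assay stays open, as does whether (2-methoxyethoxy)methyl in place of methoxy changes inhibition at all.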